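The source may report more compounds than this note shows. Statements on the series, on what has been measured and on what is new or still open speak of the compounds shown alone.

In a functional assay on DLD-1 cells (Homo sapiens) for antiproliferative activity, read by CellTiter-Glo, with a stated time of 72 h (on this read-out lower numbers stand for stronger inhibition and higher numbers for weaker inhibition), the two measured compounds share one core and differ only in the group on the sulfonyl-bearing aryl ring. Compound 1 `CC1CCN(C2CCN(S(=O)(=O)c3cccnc3F)CC2)CC1` carries a fluoropyridyl group, and compound 2 `CC1CCN(C2CCN(S(=O)(=O)c3cccc(-c4ccc5ccccc5c4)c3)CC2)CC1` carries a phenyl ring bearing a naphthalen-2-yl group. Compound 2 gives 2 nM in this assay. For compound 1 this assay reports only a limit, > 5000 nM, not a number; this is the limit of > 5000 nM in this assay, at which 1 of the 2 values shown sits. Within the data shown here, compound 2 thus holds the only numerical value in this assay, and it sits far from the limit at which compound 1 stands.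

Compound 3 `COc1cccc(S(=O)(=O)N2CCC(N3CCC(C)CC3)CC2)c1` has not yet been measured in this assay. It differs from compound 2 in one place: methoxy in place of naphthalen-2-yl on an aromatic carbon. The step from compound 2 to compound 3 therefore strips away both rings of the naphthalen-2-yl group and leaves a much smaller substituent on the aryl ring. The expectation is a large loss of activity, because compound 1, which likewise lacks a second aromatic ring system on the sulfonyl aryl group, gives > 5000 nM. Compound 3 is expected to show a step of a 1300-fold higher number from compound 2 to compound 3 (3.10 log units; beyond the scatter) toward weaker inhibition. Compound 3 is thus estimated at 2500 nM, within a range from 300 nM to 10000 nM, with a real chance that this assay again reports only a limit.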

Compound 3, half-maximal inhibitory concentration: > 5000 nM
Compound 3 gave a limit, no number (the forecaster's own chance of this, stated with the estimate: 40%); middle value at least 2.0-fold (0.30 log units) from the limit.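

Before compound 3, the only two compounds in this assay differed in the whole aromatic group on the sulfonyl sulfur, so the activity of compound 2 could not be tied to the naphthalen-2-yl group alone. Compound 3 keeps the carbon ring of compound 2 and changes only the group on its aromatic carbon, and methoxy in place of naphthalen-2-yl gives an at least 2500-fold higher number from compound 2 to compound 3 (3.39 log units; beyond the scatter), a step that rests on a limit rather than on a number for compound 3. At this position, then, the activity of compound 2 in this assay does not survive the exchange of naphthalen-2-yl for methoxy, and a second compound now stands at the edge of what the assay reports: the limit of > 5000 nM in this assay, at which 2 of the 3 values shown sit.

The step from compound 1 to compound 3 cannot be read, since both values are limits, so these two compounds cannot be ranked against each other. The compounds shown also leave open how much of the activity would remain with a single phenyl ring at this position, or with a 2-pyridyl or a dimethylamino group there.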